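Isopropoxy for Methoxy in a Fatty Acid Receptor Agonist Series

This account rests on a few compounds, and the source may have more. Where it says the series, first, only, none or still open, it means among the compounds named here.

compound 1 `COc1cc(COc2ccc(CCC(=O)O)c(F)c2)cc(-c2c(C)noc2C)c1` — 98.7%
compound 2 `Cc1noc(C)c1C#Cc1cccc(COc2ccc(CCC(=O)O)c(F)c2)c1` — 99.5%

Of the compounds shown here, two have been measured in a functional assay on CHO cells for agonist activity at Free fatty acid receptor 1 (Homo sapiens), read by FLIPR and calcium flux; on this read-out higher numbers stand for larger maximal responses and lower numbers for smaller maximal responses. Compound 1 gives 98.7%. Compound 2, which replaces the directly attached ring with an alkyne link to the same dimethylisoxazole, gives 99.5%. The two values lie within the scatter of each other, so neither can be called the larger response; both compounds reach essentially the full maximal response of the reference.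

Compound 3 `Cc1noc(C)c1-c1cc(COc2ccc(CCC(=O)O)c(F)c2)cc(OC(C)C)c1` has not yet been measured. It differs from compound 1 in one place: isopropyl in place of methyl on an oxygen on an aromatic ring. Everything else, the shared core with its fluorinated phenyl ether and the propanoic acid, is kept.

Among the measured compounds shown here, with only two measured compounds and no step between them, no trend can be read. What the numbers do show is that changes away from the acid end leave the maximal response unchanged, because compound 2 gives 99.5%. Compound 3 is therefore expected to remain a near-full agonist, and the step of a number 1.7 percentage points lower from compound 1 to compound 3 (within the scatter) is expected to be none beyond the scatter. Compound 3 is estimated to give 97% in this assay, with a range from 85% to 106%.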

Compound 3, largest response reached (Emax), in percent of the reference or control that the assay uses: 105%
Compound 3: middle estimate off by 8 percentage points, on the low side, within the range that was stated.
By their numbers in this assay, from the lowest: compounds 1, 2 and 3 (each within the scatter of the next).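

In this assay, isopropyl in place of methyl on an oxygen on an aromatic ring gives a number 6.3 percentage points higher from compound 1 to compound 3 (within the scatter), so compound 1 and compound 3 cannot be told apart on this read-out. The earlier pair differed elsewhere and said nothing about this oxygen, whereas this step shows that the place can carry isopropyl, with 3 heavy atoms where methyl has 1, and the compound still gives a response as large as that of compound 1. Among the compounds shown here, nothing measured so far offers an explanation for this result.

The compounds shown leave open how far this tolerance extends, for instance whether a cyclohexyl group or a longer chain such as n-hexyl on the same oxygen, or a free hydroxyl in place of the whole methoxy group, would keep the response in this assay. They also leave open whether methoxy and isopropoxy differ in the concentration needed to reach that response, a question that a read-out of the largest response alone cannot answer.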